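The source may hold more compounds than are shown below. What is called first, only, known or untested is meant among the compounds shown, and "the series" means these compounds.

Measured so far in a functional assay on NCI-H661 cells (Homo sapiens) for antiproliferative activity, read by MTT assay, with a stated time of 72 h; a higher number here means a weaker inhibitor of growth, a lower number a stronger inhibitor of growth:

compound 1 `O=C(COc1c(-c2ccccc2)oc2ccccc2c1=O)Nc1ccccc1`, a limit of the assay only, > 10000 nM.
compound 2 `O=C(COc1c(-c2ccccc2)oc2ccccc2c1=O)Nc1ccc(F)cc1`, a limit of the assay only, > 10000 nM.
compound 3 `O=C(COc1ccc2c(=O)c(-c3ccccc3)coc2c1)Nc1ccccc1`, a limit of the assay only, > 10000 nM.

Compound 1 and compound 2 differ by fluoro in place of hydrogen on an aromatic carbon. Both values are limits, so the step that the two limits leave unreadable from compound 1 to compound 2 stays unreadable. Compound 3 has the same atoms as compound 1, joined differently; the difference between the two cores is not broken down here. Compound 4 `O=C(COc1ccc2c(=O)c(-c3ccccc3)coc2c1)Nc1ccc(F)cc1` is not yet measured and differs from compound 3 by fluoro in place of hydrogen on an aromatic carbon, the same change as between compound 1 and compound 2, at a place described in the same words. Going by the values given here, every value known here sits at the limit of > 10000 nM in this assay, at which 3 of the 3 values shown sit; no step in the set has been read as a number.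

Compound 2 gives only a limit, > 10000 nM. On that, and on the limit for compound 3, rests the expectation that compound 4 is also expected to reach no readable value, estimated at 15000 nM. The step that the limit leaves unreadable from compound 3 to compound 4 that this estimate means is expected to be flat, with a number possibly never reported.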

Compound 4, concentration for 50% growth inhibition: > 10000 nM
Compound 4 was reported as a limit; the forecaster's own chance of this, stated with the estimate: 85%; the middle value does not contradict the limit.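

No new step can be read: compound 3 and compound 4 both give only a limit of the assay, so fluoro in place of hydrogen stays unreadable here, as it does between compound 1 and compound 2: the limit of > 10000 nM in this assay, at which 4 of the 4 values shown sit.

The compounds shown leave open whether that change matters on either core, and whether either core can reach a readable value at all.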